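The source may hold more compounds than are shown below. What is called first, only, known or untested is meant among the compounds shown, and "the series" means these compounds.

The measured compounds and their values are these:

Compound 1 `COCNc1n[n+]([O-])c2ccccc2[n+]1[O-]` gives 4270 nM in a functional assay on PC-3 cells (Homo sapiens) for cytotoxicity, read by MTT assay, with a stated time of 72 h; on this read-out lower numbers stand for stronger inhibition and higher numbers for weaker inhibition.
Compound 2 `CCCCCOCNc1n[n+]([O-])c2ccccc2[n+]1[O-]` gives 8510 nM in this assay.
Compound 3 `[O-][n+]1nc(NCOCc2ccc(Cl)cc2)[n+]([O-])c2ccccc21` gives 5100 nM in this assay.

Compound 3 stands second highest of the three numbers; its nearest neighbour is compound 1, with a 1.2-fold higher number from compound 1 to compound 3 (0.08 log units; within the scatter), and its furthest is compound 2, with a 1.7-fold lower number from compound 2 to compound 3 (0.22 log units; within the scatter), so all three lie within the scatter of one another. Compound 4 `CCOCNc1n[n+]([O-])c2ccccc2[n+]1[O-]` has not yet been measured in this assay. It differs from compound 3 by methyl in place of 4-chlorophenyl on a saturated chain carbon bound to an oxygen on a saturated carbon. For the measured compounds named here, the steps that bear on this change all sit on the same saturated chain carbon bound to an oxygen on a saturated carbon: a 2.0-fold higher number from compound 1 to compound 2 (0.30 log units; within the scatter), a 1.2-fold higher number from compound 1 to compound 3 (0.08 log units; within the scatter) and a 1.7-fold lower number from compound 2 to compound 3 (0.22 log units; within the scatter). None of them rose beyond the scatter, whether hydrogen, butyl or 4-chlorophenyl occupied that place. Compound 4 is therefore expected to show a 1.0-fold lower number from compound 3 to compound 4 (0.01 log units; within the scatter), nothing beyond the scatter. The estimate for compound 4 in this assay is 5000 nM, in a range from 2500 nM to 10000 nM.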

Compound 4, half-maximal inhibitory concentration: 7400 nM
For compound 4 the middle estimate is 1.5-fold (0.17 log units) below the measured one, and the stated range covers the measured number.
By their numbers in this assay, from the lowest: compounds 1, 3, 4 and 2 (each within the scatter of the next).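

With methyl, four groups have now occupied this saturated chain carbon bound to an oxygen on a saturated carbon, and in this assay the replacement of 4-chlorophenyl, which takes out a six-membered aromatic ring and a chlorine, stays within the scatter (a 1.5-fold higher number from compound 3 to compound 4 (0.16 log units; within the scatter)). Methyl also stays within the scatter of hydrogen (a 1.7-fold higher number from compound 1 to compound 4 (0.24 log units; within the scatter)), and trimming the chain by a propyl group does the same (a 1.2-fold lower number from compound 2 to compound 4 (0.06 log units; within the scatter)), so neither the aromatic ring nor the chain length separates these four compounds on this read-out. Nothing available explains why these steps remain so small.

As far as these compounds go, it remains open whether an amine, a carboxylic acid or a chain longer than butyl at this place would move the number beyond the scatter. From the compounds shown here alone, how any of these groups would behave on a changed core also remains open.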